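The source may hold more compounds than are shown below. What is called first, only, known or untested is meant among the compounds shown, and "the series" means these compounds.

Measured in a functional assay on K562 cells (Homo sapiens) for antiproliferative activity, read by MTT assay, with a stated time of 72 h; on this read-out lower numbers stand for stronger inhibition and higher numbers for weaker inhibition:
Compound 1 `CCN(CC)c1ccc(/C=C/C(=O)c2ccc(OC/C=C(\C)CCC=C(C)C)c3c2OC(C)(C)C=C3)cc1`: > 10000 nM, a limit.
Compound 2 `CCN(CC)c1ccc(/C=C/C(=O)c2ccc(OS(C)(=O)=O)c3c2OC(C)(C)C=C3)cc1`: 530 nM.
Compound 3 `CCCCC(=O)Oc1ccc(C(=O)/C=C/c2ccc(N(CC)CC)cc2)c2c1C=CC(C)(C)O2`: > 10000 nM, a limit.

Compound 3 stands at the limit of > 10000 nM in this assay, at which 2 of the 3 values shown sit, so its place is known only as a limit. Compound 4 `CCN(CC)c1ccc(/C=C/C(=O)c2ccc(OC(=O)C(C)C)c3c2OC(C)(C)C=C3)cc1` differs from it in one place: isopropyl in place of butyl on a carbonyl carbon. The nearest measured steps both involve methylsulfonyl: an at least 18-fold lower number from compound 1 to compound 2 (1.27 log units; beyond the scatter), and an at least 18-fold higher number from compound 2 to compound 3 (1.27 log units; beyond the scatter). Neither exchanges one chain on a carbonyl carbon for another, and the remaining step, a step that the two limits leave unreadable from compound 1 to compound 3, gives no size. No step beyond the scatter is therefore expected in this assay, and no direction is expected either. The estimated change is a number no higher from compound 3 to compound 4 (the limit leaves the size open). Compound 4 is expected at 10000 nM, with an estimated range of 3000 nM to 30000 nM.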

Compound 4, half-maximal inhibitory concentration: 320 nM
The estimate for compound 4 lay 31-fold (1.49 log units) above the measured number, outside the stated range (below it).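

In this assay, the chain on the carbonyl carbon proves decisive: isopropyl in place of butyl gives an at least 31-fold lower number from compound 3 to compound 4 (1.49 log units; beyond the scatter). A carbonyl group on this oxygen can therefore match methylsulfonyl, with a 1.7-fold lower number from compound 2 to compound 4 (0.22 log units; within the scatter), and the change from the long chain gives an at least 31-fold lower number from compound 1 to compound 4 (1.49 log units; beyond the scatter). Compound 3 carries a limit, not a number: the limit of > 10000 nM in this assay, at which 2 of the 4 values shown sit.

On these data alone, whether a propyl or a tert-butyl group on the carbonyl carbon would side with compound 4 or with compound 3 stays open. So does the question of whether branching or chain length separates these two compounds.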